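Pyridin-3-yl in Place of Phenyl on Compound 1

The compounds below may be only part of what the source reports. "The series", "measured", "known", "first", "only" and "open" are said of these compounds alone.

Measured in an assay on isolated protein for inhibition of aldehyde dehydrogenase 1A1 (Homo sapiens); on this read-out lower numbers stand for stronger inhibition and higher numbers for weaker inhibition:
compound 1 `CC(Sc1nc2nn(C3COC3)cc2c(=O)n1-c1ccccc1)c1ccccc1` gives 109 nM
compound 2 `CC(Sc1nc2nn(C3(C)COC3)cc2c(=O)n1-c1ccccc1)c1ccccc1` gives 93 nM
compound 3 `CC(Sc1nc2c(cnn2C)c(=O)n1-c1ccccc1)c1ccccc1` gives 130 nM

Compound 1 stands second highest of these three numbers; the nearest is compound 2 and the furthest is compound 3, both within the scatter. Within the data shown here, the only single-place step among them, a 1.2-fold lower number from compound 1 to compound 2 (0.07 log units; within the scatter), concerns a methyl on a saturated ring carbon and leaves the side chain untouched. Compound 4 `CC(Sc1nc2nn(C3COC3)cc2c(=O)n1-c1ccccc1)c1cccnc1` differs from compound 1 thus: pyridin-3-yl in place of phenyl on a saturated chain carbon bound to a saturated chain carbon and a sulfur. Among the measured compounds shown here, no measured step covers this change, so the expectation rests on how tightly the three numbers sit together. Compound 4 is expected to give 150 nM in this assay, with a range of 60 nM to 400 nM. That estimate means a step of a 1.4-fold higher number from compound 1 to compound 4 (0.14 log units; within the scatter), expected to stay within the scatter.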

Compound 4, half-maximal inhibitory concentration: 118 nM
For compound 4 the middle estimate is 1.3-fold (0.10 log units) above the measured one; the measured number falls inside the stated range.
By their numbers in this assay, from the lowest: compounds 2, 1, 4 and 3 (each within the scatter of the next).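

In this assay the side chain now has a reading of its own: pyridin-3-yl in place of phenyl on this saturated chain carbon gives a 1.1-fold higher number from compound 1 to compound 4 (0.03 log units; within the scatter) and so stays within the scatter. Among these compounds, the one earlier step concerned a methyl on a saturated ring carbon and left this side chain untouched. Here a ring nitrogen, with its one hydrogen-bond acceptor, enters without moving the number beyond the scatter.

Going by these compounds, what a carboxylic acid or an aminomethyl group on this aromatic ring would do remains open. Nothing available gives a reason for this result.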